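This account rests on a few compounds, and the source may have more. Where it says the series, first, only, none or still open, it means among the compounds named here.

Compound 2 `Cc1ccc(N2CCN(Cn3nc(-c4ccc5c(c4)OCCO5)oc3=S)CC2)c(C)c1` is the point of departure. Within the data shown here, in a functional assay on BGC-823 cells (Homo sapiens) for antiproliferative activity, read by MTT assay, with a stated time of 48 h (a higher number here means a weaker inhibitor, a lower number a stronger inhibitor), compound 2 gives 28300 nM, the only real number among the three measured compounds. Compound 1 `S=c1oc(-c2ccc3c(c2)OCCO3)nn1CN1CCN(C(c2ccccc2)c2ccccc2)CC1` reaches in this assay only the limit > 50000 nM. Compound 3 `Fc1ccc(N2CCN(Cn3nc(-c4ccc5c(c4)OCCO5)oc3=S)CC2)cc1` likewise reaches only the limit > 50000 nM. Compound 4 `S=c1oc(-c2ccc3c(c2)OCCO3)nn1CN1CCN(c2ccccn2)CC1` has not been measured; it differs from compound 2 by pyridin-2-yl in place of 2,4-dimethylphenyl on an amine nitrogen in a ring. Among the measured compounds shown here, one measured step bears on this change, since it also swaps the 2,4-dimethylphenyl on that ring nitrogen for a smaller aryl group: an at least 1.7-fold higher number from compound 2 to compound 3 (0.24 log units; that floor lies within the scatter). Because of the limit of > 50000 nM in this assay, at which 2 of the 3 values shown sit, a further exchange of the aryl group at this position is expected to carry compound 4 toward the same limit rather than to improve on compound 2. The step from compound 2 to compound 4 is therefore estimated as a 1.9-fold higher number from compound 2 to compound 4 (0.29 log units; within the scatter), a weakening. Compound 4 is expected to give about 55000 nM in this assay, within 20000 nM to 150000 nM, and quite possibly only as a limit.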

Compound 4, half-maximal inhibitory concentration: 25900 nM
Estimate against measurement, compound 4: 2.1-fold (0.33 log units) above, and the stated range covers the measured number.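

In this assay, exchanging 2,4-dimethylphenyl for pyridin-2-yl on the amine nitrogen in the ring gives a 1.1-fold lower number from compound 2 to compound 4 (0.04 log units; within the scatter) and leaves the two groups indistinguishable. A ring with a hetero atom and a hydrogen-bond acceptor can therefore replace the carbon-only ring at this position without a change beyond the scatter, and compound 4 gives the series a second real number where compound 2 had stood alone. The comparison with 4-fluorophenyl gives an at least 1.9-fold lower number from compound 3 to compound 4 (0.28 log units; that floor lies within the scatter) and remains only a floor, because one end of that step is a limit: the limit of > 50000 nM in this assay, at which 2 of the 4 values shown sit.

Going by these compounds, what a plain phenyl or a pyridin-4-yl would give on this ring nitrogen remains open, so the part played by the ring hetero atom cannot be separated from the loss of the two methyl groups. On these data alone, it is also open whether an amide or a carboxylic acid on this aryl ring would move the number beyond the scatter.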